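Swapping the quinolinyl arm of compound 1 for a pyridinyl

A few compounds are considered here, and "the series" means these few. Any claim that something is new, unique, unknown or untested is made for them only; others in the source may bear on it.

Compound 1 `CN(C)c1ccc(C(=O)OCC2(CO)C/C(=C\c3cnc4ccccc4c3)C(=O)O2)cc1`: 3.22
Compound 2 `CCCC(CCC)C(=O)OCC1(CO)C/C(=C/c2cccnc2)C(=O)O1`: 2.9
Compound 3 `CCCC(CCC)C(=O)OCC1(CO)C/C(=C/c2ccncc2)C(=O)O1`: 2.9

Three compounds share a lactone core carrying an ester and an exocyclic double bond to an aromatic arm. In a physicochemical assay for lipophilicity (on this read-out lower numbers stand for lower lipophilicity and higher numbers for higher lipophilicity), compound 1 gives 3.22, the highest of the three numbers; compound 2 gives 2.9 and compound 3 gives 2.9, both lower than compound 1 by a margin beyond the scatter.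

Compound 4 `CN(C)c1ccc(C(=O)OCC2(CO)C/C(=C\c3ccncc3)C(=O)O2)cc1` has not yet been measured. It differs from compound 1 in one place: pyridin-4-yl in place of quinolin-3-yl on a double-bonded chain carbon bound to a double-bonded ring carbon

Within the data shown here, only one measured step touches the aromatic arm, no change at the digits printed from compound 2 to compound 3 (within the scatter), and it shows that moving the ring nitrogen from pyridin-3-yl to pyridin-4-yl leaves the read-out unchanged. Among the measured compounds shown here, no measured step covers the loss of the fused carbon ring that the quinolin-3-yl carries; compounds 2 and 3 cannot supply it, since their ester also differs from that of compound 1. Compound 4 is therefore expected to drop in this assay by a step of about a number 1.12 log units lower from compound 1 to compound 4 (beyond the scatter), with the size uncertain. The estimate for compound 4 is 2.1, in the range 1.5 to 2.7.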

Compound 4, partition coefficient: 2.07
Compound 4: the middle estimate sits 0.03 log units above what was measured, within the range that was stated.
By their numbers in this assay, from the lowest: compound 4; then compounds 2 and 3 (each within the scatter of the next); then compound 1.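

In this assay, the change from quinolin-3-yl to pyridin-4-yl on a double-bonded chain carbon bound to a double-bonded ring carbon gives a number 1.15 log units lower from compound 1 to compound 4 (beyond the scatter) with the rest of the molecule held constant. The aromatic arm therefore can shift this read-out, which the earlier step, no change at the digits printed from compound 2 to compound 3 (within the scatter) on a different ester, did not show. The groups keep the same counts of hydrogen-bond donors and acceptors and differ in the six-membered aromatic ring of carbon only, but nothing measured here explains the step.

Going by these compounds, it remains open whether a step of this size would recur with the ester of compound 2 and compound 3. The compounds shown also leave open what a phenyl or naphthalen-2-yl group, which has no ring nitrogen, would give at this place.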